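The source may report more compounds than this note shows. Statements on the series, on what has been measured and on what is new or still open speak of the compounds shown alone.

Measured so far:
Compound 1 `Cc1cc(NS(=O)(=O)c2ccc(-c3cnc(C4CC4)o3)cc2)ccc1Cl`: > 100000 nM (a limit)
Compound 2 `Cc1cc(Cl)ccc1NS(=O)(=O)c1ccc(-c2cnc(C3CC3)o2)cc1`: > 100000 nM (a limit)

Both compounds were tested in a functional assay on cells (leukaemia cell line, Homo sapiens) for inhibition, read by sulforhodamine B assay, with a stated time of 48 h; on this read-out higher numbers stand for lower toxicity in this test and lower numbers for higher toxicity in this test. Compound 2 gives > 100000 nM, which is a limit and not a number. Compound 1 gives > 100000 nM, which is also a limit. Among the measured compounds shown here, compound 2 therefore has no exact position, and the series so far consists of the limit of > 100000 nM in this assay, at which 2 of the 2 values shown sit.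

Compound 3 `Cc1cc(Cl)cc(NS(=O)(=O)c2ccc(-c3cnc(C4CC4)o3)cc2)c1` has not yet been measured. It carries 3-chloro-5-methylphenyl in place of 4-chloro-2-methylphenyl on a sulfonamide nitrogen, with the same atoms joined differently: 3-chloro-5-methylphenyl in place of 4-chloro-2-methylphenyl on a sulfonamide nitrogen.

For the measured compounds named here, the only measured step that bears on this change is a step that the two limits leave unreadable from compound 1 to compound 2. It also moves the chlorine and methyl substituents around the phenyl group, but it offers no readable size. On that slender basis, no step beyond the usual scatter is expected in this assay, and no direction can be assigned. The estimated step is a number no higher from compound 2 to compound 3 (the limit leaves the size open). The estimate for compound 3 is 100000 nM, with an expected range of 50000 nM to 200000 nM.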

Compound 3, concentration lethal to 50% of the cells: 84900 nM
For compound 3 the middle estimate is 1.2-fold (0.07 log units) above the measured one; the range from low to high includes it.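

In this assay compound 3 gives 84900 nM as the first exact number among these compounds, so a 3-chloro-5-methylphenyl group on a sulfonamide nitrogen gives a value that can be read. The two earlier groups gave only limits. The change gives an at least 1.1-fold lower number from compound 2 to compound 3 (0.07 log units; that floor lies within the scatter) and, against the other earlier compound, an at least 1.1-fold lower number from compound 1 to compound 3 (0.07 log units; that floor lies within the scatter); each step is known only as a floor, so neither shows a change beyond the scatter, and the step between compound 1 and compound 2 still cannot be read. Rearranging the chlorine and methyl on this phenyl group has therefore produced no step of readable size, and most of the series still rests at one limit: the limit of > 100000 nM in this assay, at which 2 of the 3 values shown sit.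

As far as these compounds go, what stays open is how far the true values of compound 1 and compound 2 lie from that of compound 3, since a floor leaves the upper size of each step unknown. From the compounds shown here alone, it is also open whether a different group on this phenyl ring, such as an amine or a carboxylic acid in place of the methyl, would move the number beyond the scatter in this assay at all.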